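From an Aldehyde to a Pyridazinyl Ketone

This account rests on a few compounds, and the source may have more. Where it says the series, first, only, none or still open, it means among the compounds named here.

Compound 1, `CCCCCCCC/C=C\CCCCCCC(=O)c1ccncn1`: 110 nM in an assay on isolated protein for inhibition of Fatty-acid amide hydrolase 1 (Homo sapiens); on this read-out higher numbers stand for weaker inhibition and lower numbers for stronger inhibition
Compound 2, `CCCCCCCC/C=C\CCCCCCCC=O`: 190 nM in this assay

Among the two measured compounds, compound 2 sits at the upper end of the numbers, but the only step that separates it from compound 1, a 1.7-fold higher number from compound 1 to compound 2 (0.24 log units; within the scatter), lies within the scatter, so the two compounds are not told apart by this assay.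

Compound 3, `CCCCCCCC/C=C\CCCCCCC(=O)c1cccnn1`, has not yet been measured. It differs from compound 2 in one place: (pyridazin-3-yl)carbonyl in place of formylmethyl on a saturated chain carbon, six bonds along the chain from a double-bonded chain carbon. Among the compounds with values here, the one measured step that bears on this change is the step in the opposite sense from compound 1 to compound 2, where a heteroaryl carbonyl gave way to formylmethyl with a result of a 1.7-fold higher number from compound 1 to compound 2 (0.24 log units; within the scatter). Compound 3 reinstates a six-membered aromatic ring with two hetero atoms on the carbonyl, as in compound 1, so the expectation is a step of the same small size in the reverse direction, not beyond the scatter.

For compound 3 the estimate in this assay is therefore 120 nM, with a range from 40 nM to 400 nM, which is expected to mean a step of a 1.6-fold lower number from compound 2 to compound 3 (0.20 log units; within the scatter).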

Compound 3, inhibition constant: 130 nM
For compound 3 the middle estimate is 1.1-fold (0.03 log units) below the measured one; measured number inside the range.
By their numbers in this assay, from the lowest: compounds 1, 3 and 2 (each within the scatter of the next).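

The step to the pyridazinyl ketone, a 1.5-fold lower number from compound 2 to compound 3 (0.16 log units; within the scatter) in this assay, gives a second case of a heteroaryl carbonyl set against formylmethyl on a saturated chain carbon, six bonds along the chain from a double-bonded chain carbon, and this exchange again leaves the compounds unseparated. The new comparison on the carbonyl carbon, pyridazin-3-yl in place of pyrimidin-4-yl, is a 1.2-fold higher number from compound 1 to compound 3 (0.07 log units; within the scatter) and so shows that this change in the ring does not tell the two ketones apart in this assay, although compound 1 and compound 3 carry their ring nitrogens in different places. No measurement beyond these binding numbers is available to explain the result.

The compounds shown leave open whether a phenyl ring on the carbonyl, with no ring nitrogen, or a carboxylic acid at the end of the chain would also stay within the scatter of these values. They also leave open whether a shorter chain, or a saturated chain in place of the double bond, would move the number beyond the scatter.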